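The source may hold more compounds than are shown below. What is called first, only, known or untested is meant among the compounds shown, and "the series" means these compounds.

Within the data shown here, compound 2, `COc1nc(-c2ccncc2)ccc1[C@@H](c1ccccc1)[C@@](O)(CCN(C)C)c1cccc2ccccc12`, is the only member of this small set with a numerical cytotoxicity reading: in a toxicity assay on HeLa cells (Homo sapiens) for cytotoxicity (on this read-out higher numbers stand for lower toxicity in this test and lower numbers for higher toxicity in this test), compound 2 gives 9.6 ug/mL. Its companion compound 1, `COc1nc(-c2cccc(Cl)c2)ccc1[C@@H](c1ccccc1)[C@@](O)(CCN(C)C)c1cccc2ccccc12`, carries no number in this assay; for compound 1 the entry is "nd" (no result reported), so nothing can be said of how the two stand against one another. Compound 3, `COc1nc(-c2ccc(F)cc2)ccc1[C@@H](c1ccccc1)[C@@](O)(CCN(C)C)c1cccc2ccccc12`, has not yet been tested. It differs from compound 2 in one place only: 4-fluorophenyl in place of pyridin-4-yl on an aromatic carbon. Among the measured compounds shown here, no measured pair shows what such an exchange does to the half-maximal cytotoxic concentration, so any expectation rests on the single reading of compound 2 alone. Compound 3 is expected to land somewhat toward higher toxicity, a step of a 1.6-fold lower number from compound 2 to compound 3 (0.20 log units; within the scatter), which may or may not clear the usual scatter. The estimate for compound 3 in this assay is therefore 6 ug/mL, with a plausible range from 2.5 ug/mL to 15 ug/mL.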

Compound 3, half-maximal cytotoxic concentration: > 64 ug/mL
Compound 3: no number, only a limit; the forecaster's own chance of this, stated with the estimate: 5%; middle value at least 10-fold (1.02 log units) from the limit.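

Among these compounds, exchanging pyridin-4-yl for 4-fluorophenyl on the aromatic carbon next to the ring nitrogen gives the first readable step, and in this assay it comes to an at least 6.6-fold higher number from compound 2 to compound 3 (0.82 log units; beyond the scatter). Among the compounds shown here, for compound 3 the reading of > 64 ug/mL is a limit of the assay and not a number, so the step fixes only a minimum size and its full extent stays unknown: the limit of > 64 ug/mL in this assay, at which 1 of the 3 values shown sits. What this adds is that the half-maximal cytotoxic concentration is not indifferent to the group at this position, since compound 2, with its pyridin-4-yl ring, gives 9.6 ug/mL while the single exchange carries the reading beyond the scatter toward lower toxicity in this test.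

On these data alone, whether the step follows the loss of the ring nitrogen or the arrival of the fluorine remains open, and a plain phenyl group or a pyridin-3-yl group at this position would be needed to separate the two. Compound 1 offers no help on this point, as its entry is "nd" (no result reported), and a single pair cannot show whether the step holds for other groups at this position.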